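The compounds below may be only part of what the source reports. "The series", "measured", "known", "first", "only" and "open" are said of these compounds alone.

Measured in a functional assay on DU-145 cells (Homo sapiens) for inhibition, read by trypan blue exclusion, with a stated time of 72 h; on this read-out higher numbers stand for weaker inhibition and lower numbers for stronger inhibition:

compound 2, `O=c1c(S(=O)(=O)c2ccc(F)cc2F)cc2cnc(Nc3ccc4[nH]ccc4c3)nc2n1C1CC1`: 500 nM
compound 3, `Cn1c(=O)c(S(=O)(=O)c2ccc(F)cc2)cc2cnc(Nc3cnc4[nH]ccc4c3)nc21`: 500 nM
compound 1, `Cn1c(=O)c(S(=O)(=O)Cc2ccc(F)cc2)cc2cnc(Nc3ccc4[nH]ccc4c3)nc21`: 30000 nM

Compound 2 stands level with compound 3 at the digits shown; the two share the lowest number of the three, and the gap between them lies within the usual scatter, so no order between them can be read. Compound 1 lies furthest away, with a much higher number that sits well beyond the scatter, although compound 1 differs from compound 2 in more than one place, so its value shows only where it ends up and not what any single change does.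

Compound 4, `COC(=O)Cn1c(=O)c(S(=O)(=O)c2ccc(F)cc2F)cc2cnc(Nc3ccc4[nH]ccc4c3)nc21`, is the next step from compound 2. The change is (methoxycarbonyl)methyl in place of cyclopropyl on an aromatic nitrogen. Within the data shown here, no pair among the measured compounds isolates a change at this position, so the size of the step in this assay is not anchored by any measured step. The expectation is a modest rise in the number, that is somewhat weaker inhibition, with a fair chance that the step stays within the scatter. Compound 4 is therefore estimated at 1500 nM, with a range from 300 nM to 8000 nM. This estimate means a step of a 3.0-fold higher number from compound 2 to compound 4 (0.48 log units; beyond the scatter).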

Compound 4, half-maximal inhibitory concentration: 10000 nM
Beside the measured number, compound 4's estimate is 6.7-fold (0.82 log units) below it; the measured number lies above the stated range.
By their numbers in this assay, from the lowest: compounds 2 and 3 (each within the scatter of the next); then compound 4; then compound 1.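

Among these compounds, this is the first step that isolates the group on this aromatic nitrogen, and in this assay the change from cyclopropyl to (methoxycarbonyl)methyl gives a 20-fold higher number from compound 2 to compound 4 (1.30 log units; beyond the scatter). With the rest of compound 2 held fixed, the group on this nitrogen alone is thus enough to move the number by a large margin, so the position is not indifferent to what it carries. The change swaps a three-membered carbon ring for an open chain with a double bond outside the aromatic rings and two hydrogen-bond acceptors, but no available evidence says which of these differences matters.

Going by these compounds, whether the step follows from losing the ring or from gaining the ester remains open; a plain ethyl chain on this nitrogen, or a carboxylic acid in place of the methyl ester, would bear on that question. On these data alone, it also remains open whether the step would keep its size alongside the other features of compound 1 and compound 3, which differ from compound 2 in more than one place.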